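Changing the amide substituent at similar solubility

A few compounds are considered here, and "the series" means these few. Any claim that something is new, unique, unknown or untested is made for them only; others in the source may bear on it.

In a physicochemical assay for solubility, read by spectrophotometry, measured as kinetic solubility, at pH 8, tested at 500 uM (a lower number here means a less soluble compound, a higher number a more soluble compound), compound 1 `CN(C)C(=O)c1ccncc1Nc1cc(-c2ccc3ccn(C)c3c2)c2nccnc2c1` gives 175 ug/mL and compound 2 `Cn1ccc2ccc(-c3cc(Nc4cnccc4C(=O)NCc4cncnc4)cc4nccnc34)cc21` gives 233 ug/mL, so the two values lie within the scatter of each other. Compound 3 `Cn1cc(NC(=O)c2ccncc2Nc2cc(-c3ccc4ccn(C)c4c3)c3nccnc3c2)cn1` keeps the shared core of compound 2 and changes the group on an amide-type nitrogen: 1-methyl-1H-pyrazol-4-yl in place of (pyrimidin-5-yl)methyl on an amide-type nitrogen.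

Going by the values given here, only one measured step bears on this change, and it concerns the same amide substituent: a 1.3-fold higher number from compound 1 to compound 2 (0.12 log units; within the scatter). That single step stayed within the scatter, although it exchanged dimethylamino for ((pyrimidin-5-yl)methyl)amino. Among the compounds with values here, no measured compound yet carries 1-methyl-1H-pyrazol-4-yl, so the evidence is thin and the range is kept wide. No shift beyond the scatter is expected in either direction, and the estimated change is a 1.3-fold lower number from compound 2 to compound 3 (0.11 log units; within the scatter). For compound 3 the expected value is 180 ug/mL, with an estimated range of 85 ug/mL to 245 ug/mL.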

Compound 3, solubility: 2 ug/mL
Estimate against measurement, compound 3: 90-fold (1.95 log units) above; the measured number lies below the stated range.
By their numbers in this assay, from the lowest: compound 3; then compounds 1 and 2 (each within the scatter of the next).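

In this assay the group on the amide-type nitrogen proves far from indifferent: compound 3 stands well apart from its neighbours (a 120-fold lower number from compound 2 to compound 3 (2.07 log units; beyond the scatter)) (an 88-fold lower number from compound 1 to compound 3 (1.94 log units; beyond the scatter)) although the exchange linking compound 1 and compound 2 stayed within the scatter (a 1.3-fold higher number from compound 1 to compound 2 (0.12 log units; within the scatter)). The counts of hydrogen-bond donors and acceptors and the net charge are the same for (pyrimidin-5-yl)methyl and 1-methyl-1H-pyrazol-4-yl, so these counts do not separate compound 2 from compound 3. What does differ is a six-membered against a five-membered aromatic ring, and a ring held on a methyl link against one set directly on the nitrogen.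

Which of these differences matters stays open, and a (1-methyl-1H-pyrazol-4-yl)methyl group or a pyrimidin-5-yl group set directly on the nitrogen would pull them apart. Nothing measured here accounts for the gap.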